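This account rests on a few compounds, and the source may have more. Where it says the series, first, only, none or still open, it means among the compounds named here.

In a functional assay on MCF7 cells (Homo sapiens) for antiproliferative activity, read by MTT assay, with a stated time of 72 h (on this read-out higher numbers stand for weaker inhibition and lower numbers for stronger inhibition), compound 1 `C/C=C/C(=O)Nc1cccc(Oc2nc(Nc3cccc(OC)c3)nc3c2CSCC3)c1` gives 23400 nM and compound 3 `COc1cccc(Nc2nc3c(c(Oc4cccc(NC(=O)/C=C/C(C)C)c4)n2)CSCC3)c1` gives 21800 nM. Compound 2 `COc1cccc(Nc2nc3c(c(Oc4cccc(NC(=O)C=C(C)C)c4)n2)CSCC3)c1` gives > 50000 nM, which is a limit and not a number: the limit of > 50000 nM in this assay, at which 1 of the 3 values shown sits. Compound 4 `COc1ccc(Nc2nc3c(c(Oc4cccc(NC(=O)C=C(C)C)c4)n2)CSCC3)cn1` keeps the group on the carbonyl carbon of compound 2 but carries 6-methoxypyridin-3-yl in place of 3-methoxyphenyl on a nitrogen on an aromatic ring. The measured steps all alter the group on the carbonyl carbon. Two lie beyond the scatter, an at least 2.1-fold higher number from compound 1 to compound 2 (0.32 log units; beyond the scatter) and an at least 2.2-fold lower number from compound 2 to compound 3 (0.36 log units; beyond the scatter), while a 1.1-fold lower number from compound 1 to compound 3 (0.03 log units; within the scatter) lies within it. None of them changes the group on that nitrogen, so none gives a size for this change. The expected result is a number no higher from compound 2 to compound 4 (the limit leaves the size open), with no step beyond the scatter expected in this assay. For compound 4 the estimate is 50000 nM, with an expected range of 20000 nM to 120000 nM.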

Compound 4, half-maximal inhibitory concentration: 22200 nM
Beside the measured number, compound 4's estimate is 2.3-fold (0.35 log units) above it, within the range that was stated.
By their numbers in this assay, from the lowest: compounds 3, 4 and 1 (each within the scatter of the next). At a limit, above all of these: compound 2.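

In this assay, for the compounds shown here, changing the group on the nitrogen while the group on the carbonyl carbon stays fixed gives an at least 2.2-fold lower number from compound 2 to compound 4 (0.35 log units; beyond the scatter) as the first step at this position. It shows that this group, and not only the group on the carbonyl carbon, can move the number. The value of compound 2 is a limit and not a number: the limit of > 50000 nM in this assay, at which 1 of the 4 values shown sits.

Going by these compounds, whether the same change gives a similar step with the groups on the carbonyl carbon of compound 1 or compound 3 stays open. Also open, on these data alone, is what an ethoxy group or an amine would give in place of the methoxy of 6-methoxypyridin-3-yl.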